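The compounds below may be only part of what the source reports. "The series", "measured", "known", "first", "only" and "open" are said of these compounds alone.

Three compounds sharing one core and differing only in the amine on a thiocarbonyl carbon have been tested in a functional assay on HEp-2 cells (Homo sapiens) for antiproliferative activity, read by MTT assay, with a stated time of 72 h; on this read-out lower numbers stand for stronger inhibition and higher numbers for weaker inhibition. Compound 1 `O=c1c(Cl)c(CSC(=S)N2CCCCC2)oc2ccccc12` gives 940 nM. Compound 2 `CC(C)N(C(=S)SCc1oc2ccccc2c(=O)c1Cl)C(C)C` gives 20000 nM. Compound 3 `O=c1c(Cl)c(CSC(=S)N2CCCC2)oc2ccccc12` gives 600 nM, standing at the low end of the three numbers, with compound 1 close by and compound 2 far off. The steps are a 1.6-fold lower number from compound 1 to compound 3 (0.19 log units; within the scatter) and a 21-fold higher number from compound 1 to compound 2 (1.33 log units; beyond the scatter). Compound 4 `O=c1c(Cl)c(CSC(=S)N2CCOCC2)oc2ccccc12` carries morpholin-4-yl in place of pyrrolidin-1-yl on a thiocarbonyl carbon. The first step shows that exchanging one ring amine for another changed little, while the large loss in the second step came with the open-chain diisopropylamino group. A step within the scatter, or at most a modest rise, is therefore expected: a 2.0-fold higher number from compound 3 to compound 4 (0.30 log units; within the scatter). Compound 4 is estimated at 1200 nM, with a range from 400 nM to 4000 nM.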

Compound 4, half-maximal inhibitory concentration: 9000 nM
The estimate for compound 4 lay 7.5-fold (0.88 log units) below the measured number; measured number above the stated range.
By their numbers in this assay, from the lowest: compounds 3 and 1 (each within the scatter of the next); then compound 4; then compound 2.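

Ring amines on this thiocarbonyl carbon are not interchangeable: morpholin-4-yl brings a 15-fold higher number from compound 3 to compound 4 (1.18 log units; beyond the scatter) and also a 9.6-fold higher number from compound 1 to compound 4 (0.98 log units; beyond the scatter) and so a ring alone does not keep the number low. The open-chain diisopropylamino group is no longer alone in giving a high number, although a 2.2-fold lower number from compound 2 to compound 4 (0.35 log units; beyond the scatter) still separates it from morpholin-4-yl. Nothing measured here explains the loss seen with morpholin-4-yl. Going by these compounds, whether that loss follows the ring oxygen itself stays open. So does how thiomorpholin-4-yl or piperazin-1-yl, with sulfur or a second nitrogen instead of that oxygen, would compare.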